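The source may hold more compounds than are shown below. What is called first, only, known or untested is meant among the compounds shown, and "the series" means these compounds.

Measured compounds:
compound 1, `Clc1ccc(C2CC(c3ccc(N4CCCCC4)cc3)=NN2c2nc(-c3ccccc3)cs2)cc1` — in a functional assay on MCF7 cells (Homo sapiens) for antiproliferative activity, read by MTT assay, with a stated time of 72 h (on this read-out lower numbers stand for stronger inhibition and higher numbers for weaker inhibition), compound 1 gives 28400 nM.
compound 2, `COc1ccc(-c2csc(N3N=C(c4ccc(N5CCCCC5)cc4)CC3c3ccc(Cl)cc3)n2)cc1` — in this assay compound 2 gives > 100000 nM, which is a limit of the assay and not a number.

Among the measured compounds shown here, compound 1 is the only compound here with a numeric value in this assay; the other value is a limit. For the measured compounds named here, the one measured step, an at least 3.5-fold higher number from compound 1 to compound 2 (0.54 log units; beyond the scatter), runs towards (the limit of > 100000 nM in this assay, at which 1 of the 2 values shown sits). Compound 3, `CS(=O)(=O)c1ccc(-c2csc(N3N=C(c4ccc(N5CCCCC5)cc4)CC3c3ccc(Cl)cc3)n2)cc1`, has not yet been measured. It differs from compound 1 by methylsulfonyl in place of hydrogen on an aromatic carbon. Going by the values given here, the change sits at the same aromatic carbon as the one from compound 1 to compound 2, so that step is the only guide. On it, compound 3 is expected to give a weaker result than compound 1, with the step of a 2.3-fold higher number from compound 1 to compound 3 (0.36 log units; beyond the scatter) expected to lie beyond the scatter. Compound 3 is therefore estimated at 65000 nM, within a range from 20000 nM to 200000 nM, with a real chance that only a limit is reported.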

Compound 3, half-maximal inhibitory concentration: > 100000 nM
Compound 3: only a limit was reported; the forecaster's own chance of this, stated with the estimate: 50%; middle value at least 1.5-fold (0.18 log units) from the limit.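

In this assay compound 3 gives > 100000 nM, which is a limit of the assay and not a number. Methylsulfonyl on this aromatic carbon therefore points the same way as methoxy did, with an at least 3.5-fold higher number from compound 1 to compound 3 (0.54 log units; beyond the scatter). Among the compounds shown, both groups placed here give a weaker result than hydrogen, none goes against this, and the series now gathers at one ceiling: the limit of > 100000 nM in this assay, at which 2 of the 3 values shown sit.

Both values for compound 2 and compound 3 are limits, so the step between them cannot be read and methoxy and methylsulfonyl cannot be ranked against each other. As far as these compounds go, it remains open whether a smaller group on this carbon, such as fluorine, a hydroxyl or an amine, would keep a numeric value in this assay, and these compounds give no cause for the loss.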